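Three Low Readings and an Untested Ring Swap

A few compounds are considered here, and "the series" means these few. Any claim that something is new, unique, unknown or untested is made for them only; others in the source may bear on it.

Of the compounds shown here, three have so far been tested in a functional assay on the whole organism (blood) with Rattus norvegicus as the target, with stated times of 24 h and 1 h, at a dose of 5 mg/kg by the intraperitoneal route; on this read-out lower numbers stand for a weaker effect and higher numbers for a stronger effect at the one dose given. Compound 1, `CCCCCCNC(=O)NS(=O)(=O)N1CCC(CNC(=O)c2cc(Cl)ccc2OC)CC1`, gives 17%. Compound 2, `O=C(NC1CCCCC1)NS(=O)(=O)N1CCC(CCNC(=O)C(F)(F)F)CC1`, gives 13%. Compound 3, `Cc1ncsc1C(=O)NCCC1CCN(S(=O)(=O)NC(=O)NC[C@@H]2C[C@@H]3C=C[C@@H]2C3)CC1`, gives 11%. On these numbers compound 3 holds the lowest reading, but the gap to compound 2, its nearest neighbour, and the gap to compound 1, the furthest away, both fall within the usual scatter of repeated measurements, so none of the three can be called stronger or weaker than another; all three sit at the low end of the scale.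

Compound 4, `Cn1cc(C(=O)NCCC2CCN(S(=O)(=O)NC(=O)NC[C@@H]3C[C@@H]4C=C[C@@H]3C4)CC2)c(=O)n(C)c1=O`, has not yet been measured in this assay. It differs from compound 3 in one place: a group of 10 heavy atoms (6 carbon, 2 nitrogen, 2 oxygen; one six-membered aromatic ring with 2 hetero atoms) in place of a group of 6 heavy atoms (4 carbon, 1 nitrogen, 1 sulfur; one five-membered aromatic ring with 2 hetero atoms), on a carbonyl carbon. Within the data shown here, no two measured compounds differ by this change, so there is no measured step that shows what it does. With every measured compound giving a similar low reading, the change from compound 3 to compound 4 is expected to move the number by a number 2 percentage points higher from compound 3 to compound 4 (within the scatter), which is no shift beyond the scatter. Compound 4 is therefore estimated to give 13% in this assay, with a range from 3% to 27%.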

Compound 4, a percentage reported as activity, at one dose (the size of the read-out at that dose, not a potency): 23%
Compound 4: middle estimate off by 10 percentage points, on the low side; the measured number falls inside the stated range.
By their numbers in this assay, from the lowest: compounds 3, 2, 1 and 4 (each within the scatter of the next, the first and the last beyond it).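

Among these compounds, exchanging the 4-methyl-1,3-thiazol-5-yl group on this carbonyl carbon for the larger group of compound 4 gives the first step that can be read in this assay: the reading moves a number 12 percentage points higher from compound 3 to compound 4 (beyond the scatter), a modest shift. The earlier compounds shown here all sat within the scatter of one another and offered no pair differing in one place, so they could not show whether anything done here changes the reading. This single pair shows that the position does respond to the group it carries, with the five-membered aromatic ring giving way to a six-membered aromatic ring with 2 hetero atoms and 2 double bonds outside aromatic rings, and no measurement at hand says which of these differences accounts for the rise.

The compounds shown leave open whether a plain pyridine ring on the same carbonyl carbon would read like compound 3 or like compound 4. They also leave open whether the same exchange would bring a step of similar size to a compound otherwise resembling compound 2.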